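Imine series: cytotoxicity on HeLa, step from compound 3 to compound 4

This account rests on a few compounds, and the source may have more. Where it says the series, first, only, none or still open, it means among the compounds named here.

Working notes. Going by the values given here, in an ADME assay on HeLa cells (Homo sapiens) for cytotoxicity, read by MTT assay, with a stated time of 72 h (a higher number here means that more compound is tolerated, a lower number that less compound is tolerated), compound 3 `Clc1ccc(/C=N/c2sc3c(c2-c2nc4ccccc4s2)CCCC3)cc1` gives 431 ug/mL, the highest of the three numbers so far. Compound 2 `Fc1ccccc1/C=N/c1sc2c(c1-c1nc3ccccc3s1)CCC2` gives 355 ug/mL, within the scatter of compound 3. Compound 1 `Nc1sc2c(c1-c1nc3cc(Cl)ccc3s1)CCCC2` gives 107 ug/mL, well below compound 3 and beyond the scatter. Among the compounds with values here, no step between measured compounds is available for the change now considered. Compound 4 `Fc1ccccc1/C=N/c1sc2c(c1-c1nc3ccccc3s1)CCCC2` differs from compound 3 only by 2-fluorophenyl in place of 4-chlorophenyl on a carbon with a double bond to nitrogen. Compound 2 also carries a 2-fluorophenyl and its reading of 355 ug/mL sits close to compound 3, so in this assay no shift beyond the scatter is expected for compound 4, the expected step being a 1.1-fold lower number from compound 3 to compound 4 (0.05 log units; within the scatter). Compound 4 is estimated at 380 ug/mL, within a range from 200 ug/mL to 720 ug/mL.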

Compound 4, half-maximal cytotoxic concentration: 426 ug/mL
The estimate for compound 4 lay 1.1-fold (0.05 log units) below the measured number; low and high end bracket the measured number.
By their numbers in this assay, from the lowest: compound 1; then compounds 2, 4 and 3 (each within the scatter of the next).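

In this assay, going by these compounds alone, 2-fluorophenyl in place of 4-chlorophenyl on a carbon with a double bond to nitrogen gives a 1.0-fold lower number from compound 3 to compound 4 (0.01 log units; within the scatter), the only step so far between compounds differing in one place. At this place, the two groups cannot be told apart by this read-out. Nothing on hand bears on why the two compounds read alike. On these data alone, whether an amine, a carboxylic acid or a longer chain at this place would shift the number stays open. So does whether the same exchange would read alike on the core of compound 2.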